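From isopropoxy to (methylsulfonyl)oxy on a shared core

A few compounds are considered here, and "the series" means these few. Any claim that something is new, unique, unknown or untested is made for them only; others in the source may bear on it.

In a functional assay on A549 cells (Homo sapiens) for cytotoxicity (a lower number here means that less compound is needed, a higher number that more compound is needed for the effect), compound 1 `CC(C)Oc1cc(-c2ccccc2)nc2ccccc12` gives > 10 ug/mL as a limit of the assay, not a number. Among the measured compounds shown here, compound 2 `Oc1ccc2c(O)cc(-c3ccccc3)nc2c1` gives 0.81 ug/mL in this assay as a measured number, but it differs from compound 1 in more than one place and offers no single-change step. Compound 3 `CS(=O)(=O)Oc1cc(-c2ccccc2)nc2ccccc12` carries methylsulfonyl in place of isopropyl on an oxygen on an aromatic ring and keeps the core of compound 1. For the measured compounds named here, no measured pair isolates this change, so the expectation rests on compound 1 and its limit of > 10 ug/mL alone. The expected step of an at least 1.2-fold lower number from compound 1 to compound 3 (0.09 log units; that floor lies within the scatter) in this assay is small, points toward less compound being needed, and may stay within the usual scatter. Compound 3 is estimated at 8 ug/mL in this assay with an expected range from 2.5 ug/mL to 25 ug/mL and may yet read only as a limit.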

Compound 3, half-maximal effective concentration: 6.21 ug/mL
Estimate against measurement, compound 3: 1.3-fold (0.11 log units) above; the measured number falls inside the stated range.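

With (methylsulfonyl)oxy in place of isopropoxy on the shared core, compound 3 gives a measured number in this assay, so this position now yields a reading on the scale of the assay. Compound 1, by contrast, gives > 10 ug/mL, which is a limit of the assay and not a number. The change amounts to an at least 1.6-fold lower number from compound 1 to compound 3 (0.20 log units; that floor lies within the scatter), and its true size stays unknown because the starting point is only a limit: the limit of > 10 ug/mL in this assay, at which 1 of the 3 values shown sits.

The compounds shown do not tell whether the reading of compound 3 depends on the methylsulfonyl group itself or only on the loss of isopropyl. They also leave open how an acetyl group, a longer sulfonyl chain such as ethylsulfonyl, or a phenylsulfonyl group would read on the same oxygen of the shared core.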